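Adding a Fluoro to the Trifluoromethylbenzyl Arm

This account rests on a few compounds, and the source may have more. Where it says the series, first, only, none or still open, it means among the compounds named here.

Three measured compounds share one core and differ only in the group on the benzyl ring. Compound 1 `COc1ccccc1Cn1cnnc1-c1cccc(Cl)c1Cl` carries methoxy; in a functional assay for antagonist activity at P2X purinoceptor 7 (Homo sapiens) (on this read-out higher numbers stand for weaker inhibition and lower numbers for stronger inhibition), compound 1 gives 191 nM. Compound 2 `FC(F)(F)c1ccccc1Cn1cnnc1-c1cccc(Cl)c1Cl` carries trifluoromethyl, and in this assay compound 2 gives 132 nM. Compound 3 `CSc1ccccc1Cn1cnnc1-c1cccc(Cl)c1Cl` carries methylsulfanyl; in this assay compound 3 gives 49 nM. The step of a 1.4-fold lower number from compound 1 to compound 2 (0.16 log units; within the scatter) stays within the scatter, whereas a 3.9-fold lower number from compound 1 to compound 3 (0.59 log units; beyond the scatter) and a 2.7-fold lower number from compound 2 to compound 3 (0.43 log units; beyond the scatter) go beyond it. Compound 2 thus stands second highest of the three numbers, close to compound 1 and apart from compound 3.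

Compound 4 `Fc1ccc(C(F)(F)F)c(Cn2cnnc2-c2cccc(Cl)c2Cl)c1` keeps the trifluoromethyl of compound 2 and adds a further change: fluoro in place of hydrogen on an aromatic carbon. Going by the values given here, none of the measured steps involves an added fluoro; each of them exchanges the group already on the ring, so they bear on this change only loosely. Those steps range from within the scatter to modest, and one added fluoro gives no ground to expect more. The author therefore expects the step of a 1.1-fold lower number from compound 2 to compound 4 (0.04 log units; within the scatter) in this assay to remain within the scatter. For compound 4 in this assay the estimate is 120 nM, with a range from 50 nM to 300 nM.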

Compound 4, half-maximal inhibitory concentration: 49 nM
Beside the measured number, compound 4's estimate is 2.4-fold (0.39 log units) above it; the measured number lies below the stated range.
By their numbers in this assay, from the lowest: compounds 3 and 4 (each within the scatter of the next); then compounds 2 and 1 (each within the scatter of the next).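

In this assay, compound 4 shows that a hydrogen on this ring, at the carbon para to a trifluoromethyl group and meta to a large group, is not a silent place: replacing it with fluoro, a single heavy atom, gives a 2.7-fold lower number from compound 2 to compound 4 (0.43 log units; beyond the scatter). The earlier compounds shown here showed changes only in the group already on the ring, and on the printed numbers this added fluoro moves the value as far as the full exchange of trifluoromethyl for methylsulfanyl, a 2.7-fold lower number from compound 2 to compound 3 (0.43 log units; beyond the scatter). Nothing shown here explains why the added fluoro has this effect.

From the compounds shown here alone, whether the step belongs to fluoro in particular remains open, since these compounds do not tell how a nitrile or an amine at the same carbon would read. Going by these compounds, it also remains open whether the added fluoro would give a step of like size alongside the methoxy of compound 1 or the methylsulfanyl of compound 3, and whether the other carbons of this ring would respond in the same way.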